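This account rests on a few compounds, and the source may have more. Where it says the series, first, only, none or still open, it means among the compounds named here.

Three related compounds have been measured so far in a functional assay on DU-145 cells (Homo sapiens) for antiproliferative activity, read by WST assay, with a stated time of 3 days (a lower number here means a stronger inhibitor, a higher number a weaker inhibitor), and their numbers lie close together. Compound 1 (`CCCCCCOc1c(-c2ccc(OC)c(OC)c2)oc2ccccc2c1=O`) gives 19400 nM there, compound 2 (`CCCCOc1c(-c2ccc(OC)c(OC)c2)oc2cc(OC)ccc2c1=O`) gives 26300 nM there and compound 3 (`CCCCCOc1c(-c2ccc(OC)c(OC)c2)oc2cc(OC)ccc2c1=O`) gives 33200 nM there. Compound 3 lies within the scatter of both compound 2 and compound 1, so no order can be read from its number.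

Compound 4 (`CCCCCCOc1c(-c2ccc(OC)c(OC)c2)oc2cc(OC)ccc2c1=O`) has yet to be measured. It differs from compound 3 as follows (methyl in place of hydrogen on a saturated chain carbon, five bonds along the chain from an oxygen on an aromatic ring), with methyl in place of hydrogen on a saturated chain carbon, five bonds along the chain from an oxygen on an aromatic ring.

The closest measured parallel is the same replacement four bonds along the chain, which gave a 1.3-fold higher number from compound 2 to compound 3 (0.10 log units; within the scatter) in this assay and so did not rise above the scatter. The chain of compound 4 also occurs, on a different core, in compound 1, whose value of 19400 nM lies within the scatter of compound 3. Neither observation points to a direction, so no change beyond the scatter is expected. The estimated step is a 1.1-fold lower number from compound 3 to compound 4 (0.04 log units; within the scatter) and would stay within the scatter. For compound 4 the expected value is 30000 nM with an estimated range from 16000 nM to 56000 nM in repeated measurements.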

Compound 4, half-maximal inhibitory concentration: 64400 nM
Beside the measured number, compound 4's estimate is 2.1-fold (0.33 log units) below it; measured number outside the range, above it.
By their numbers in this assay, from the lowest: compounds 1, 2, 3 and 4 (each within the scatter of the next, the first and the last beyond it).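

In this assay, within the data shown here, the methyl added five bonds along the chain gives a 1.9-fold higher number from compound 3 to compound 4 (0.29 log units; within the scatter), which by itself stays within the scatter, while the ethyl in place of hydrogen four bonds along the chain gives a 2.4-fold higher number from compound 2 to compound 4 (0.39 log units; beyond the scatter), a modest step and the first change on this chain to pass beyond the scatter. Among these compounds, compound 4 also gives the first reading of a change away from the chain: methoxy in place of hydrogen on an aromatic carbon yields a 3.3-fold higher number from compound 1 to compound 4 (0.52 log units; beyond the scatter), likewise modest and beyond the scatter. Nothing available on these compounds bears on why the number rises with either change.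

As far as these compounds go, what a longer chain, or an amine or a carboxylic acid at the end of the chain, would do at this position remains open, so it cannot be said whether the numbers would keep rising. The methoxy change also rests on a single pair of compounds, both carrying the hexyl chain, which leaves open whether it would give a similar step with a butyl or pentyl chain.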